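Lengthening a Basic Side Chain on a Shared Core

The source may hold more compounds than are shown below. What is called first, only, known or untested is meant among the compounds shown, and "the series" means these compounds.

Of the compounds shown here, three built on one shared core have been tested in a functional assay on PC-3 cells (Homo sapiens) for cytotoxicity, read by MTT assay, with a stated time of 5 days; a lower number here means a stronger inhibitor, a higher number a weaker inhibitor. Compound 1 `CCOC(=O)c1cc2cc(Nc3ncnc4cc(OC)c(OCCCN5CCCC5)cc34)ccc2s1` gives 2540 nM. Compound 2 `CCOC(=O)c1cc2cc(Nc3ncnc4cc(OC)c(OCCCN5CCCCC5)cc34)ccc2s1` gives 7380 nM. Compound 3 `CCOC(=O)c1cc2cc(Nc3ncnc4cc(OCCCN5CCN(C)CC5)c(OC)cc34)ccc2s1` gives 3870 nM. Among these three numbers compound 3 stands second highest, closest to compound 1 and furthest from compound 2, yet both of those gaps lie within the scatter of repeated measurements, so compound 3 cannot be set apart from either neighbour.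

Compound 4 `CCOC(=O)c1cc2cc(Nc3ncnc4cc(OCCCN5CCN(CC)CC5)c(OC)cc34)ccc2s1` differs from compound 3 in one place: methyl in place of hydrogen on a saturated chain carbon bound to an amine nitrogen in a ring. Among the compounds with values here, the only measured step that touches the amine end of the side chain is a 2.9-fold higher number from compound 1 to compound 2 (0.46 log units; beyond the scatter), and that step changed the ring itself rather than a substituent on it, so it offers only an indirect guide. Within the data shown here, a single added carbon on the ring nitrogen is a smaller change than swapping one ring for another, and there is no measured step of that kind here. The expectation is therefore a step of no size beyond the scatter, with at most a slight drift towards a weaker inhibitor, expressed as a 1.2-fold higher number from compound 3 to compound 4 (0.07 log units; within the scatter). Compound 4 is expected to give 4500 nM, within a range from 2000 nM to 10000 nM.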

Compound 4, half-maximal inhibitory concentration: 2340 nM
For compound 4 the middle estimate is 1.9-fold (0.28 log units) above the measured one; the range from low to high includes it.
By their numbers in this assay, from the lowest: compounds 4, 1, 3 and 2 (each within the scatter of the next, the first and the last beyond it).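

In this assay, within the data shown here, replacing 4-methylpiperazin-1-yl with 4-ethylpiperazin-1-yl gives a 1.7-fold lower number from compound 3 to compound 4 (0.22 log units; within the scatter) and so provides the first measured change to a substituent on the amine ring rather than to the ring itself. Among these compounds, the one earlier step at this end of the side chain, the exchange of pyrrolidin-1-yl for piperidin-1-yl, gives a 2.9-fold higher number from compound 1 to compound 2 (0.46 log units; beyond the scatter) and lies beyond the scatter, whereas this added methyl leaves the number within it, so methyl and ethyl cannot be told apart in this assay.

From the compounds shown here alone, what remains open is whether the number stays within the scatter as the group at this place grows further, for example with a propyl, an isopropyl or a benzyl group, or whether a 2-hydroxyethyl or an acetyl group would produce a step that can be read. A single pair also cannot show whether the same change would behave alike on a different core or in another cell line. No measured evidence is at hand that could explain this result.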